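Terminal phenyl substituent exchange: acetyl to dimethylamino

The compounds below may be only part of what the source reports. "The series", "measured", "known", "first", "only" and "open" are said of these compounds alone.

Compound 1 `COc1cc(C)cc(-c2c(-c3ccnc(-c4ccc(C(C)=O)cc4)c3)cnn2CC#N)c1` and compound 2 `Cc1cc(O)cc(-c2nn(CC#N)cc2-c2ccnc(-c3ccc(Oc4ccccc4)cc3)c2)c1` share a core but differ at more than one place, so no single change separates them. In a functional assay on MDA-MB-231 cells (Homo sapiens) for inhibition, read by sulforhodamine B assay, with a stated time of 48 h (on this read-out lower numbers stand for stronger inhibition of growth and higher numbers for weaker inhibition of growth), compound 1 gives 3630 nM, and compound 2 gives 2280 nM. Compound 1 carries the higher of the two numbers, yet the gap to compound 2 lies within the scatter, so the two values cannot be ordered against each other. Going by the values given here, no step between measured compounds that differ in one place is available, and the series therefore offers no measured guide to the size of any single substituent change.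

Compound 3 `COc1cc(C)cc(-c2c(-c3ccnc(-c4ccc(N(C)C)cc4)c3)cnn2CC#N)c1` remains to be measured in this assay. It differs from compound 1 in one place: dimethylamino in place of acetyl on an aromatic carbon. The two measured values have no bearing on this exchange, and both sit in the same region. For compound 3 the step of a 1.3-fold lower number from compound 1 to compound 3 (0.11 log units; within the scatter) is expected to remain within the scatter, with no firm direction. Compound 3 is thus estimated at 2800 nM, with a range from 900 nM to 9000 nM.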

Compound 3, concentration for 50% growth inhibition: 256 nM
Estimate against measurement, compound 3: 11-fold (1.04 log units) above, and the stated range ends above it.
By their numbers in this assay, from the lowest: compound 3; then compounds 2 and 1 (each within the scatter of the next).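

In this assay, going by these compounds alone, dimethylamino in place of acetyl on an aromatic carbon, para to a large group, gives a 14-fold lower number from compound 1 to compound 3 (1.15 log units; beyond the scatter) and so supplies the first single-place step, one well beyond the scatter. This position therefore responds strongly to the identity of its substituent, even though acetyl and dimethylamino have the same count of heavy atoms, the same counts of hydrogen-bond donors and acceptors, and no net charge. The counted differences are that a nitrogen enters, while an oxygen and the double bond outside aromatic rings leave, and no accompanying measurement shows which feature of the exchange accounts for the size of the step.

On these data alone, with only acetyl and dimethylamino compared here, it remains open whether other nitrogen substituents such as a primary amine, diethylamino or morpholine would give a number like that of compound 3 or one like that of compound 1. As far as these compounds go, it is also open whether the same exchange would produce a step of similar size with the other parts of the core of compound 1 changed.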